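This account rests on a few compounds, and the source may have more. Where it says the series, first, only, none or still open, it means among the compounds named here.

Measured so far in a functional assay on MCF7 cells (Homo sapiens) for inhibition, read by sulforhodamine B assay, with a stated time of 48 h; a higher number here means a weaker inhibitor, a lower number a stronger inhibitor:
Compound 1, `CCNC(=O)Nc1ccc(/C=C/c2cccc(Cl)c2)cc1`, gives 20000 nM.
Compound 2, `CCNC(=O)Nc1ccc(/C=C/c2cc(C)cc(C)c2)cc1`, gives 20000 nM.
Compound 3, `Cc1cc(C)cc(/C=C\c2ccc(N3CCNC3=O)cc2)c1`, gives 23 nM.

Compound 3 has the lowest number of the three; compound 1 and compound 2 both stand far above it, beyond the scatter. Compound 4, `Cc1cc(C)cc(/C=C/c2ccc(N3CCNC3=O)cc2)c1`, differs from compound 3 only as drawn: the two compounds have the same atoms and bonds and differ only in configuration as drawn: 1 of 1 stereo elements differ; a double bond is drawn Z in compound 3 and E in compound 4. Within the data shown here, no measured pair shows this change alone. Compound 1 and compound 2 also carry a double bond drawn E, yet they differ from compound 4 elsewhere, so their values can only hint. A large upward step a 220-fold higher number from compound 3 to compound 4 (2.34 log units; beyond the scatter) in this assay is expected, since compound 1 gives 20000 nM and compound 2 gives 20000 nM. Compound 4 is estimated at 5000 nM, between 800 nM and 25000 nM.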

Compound 4, half-maximal inhibitory concentration: 16000 nM
For compound 4 the middle estimate is 3.2-fold (0.51 log units) below the measured one; low and high end bracket the measured number.
By their numbers in this assay, from the lowest: compound 3; then compounds 4, 1 and 2 (each within the scatter of the next).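

In this assay, among these compounds, inverting the double bond alone gives a 700-fold higher number from compound 3 to compound 4 (2.84 log units; beyond the scatter), a separation the earlier compounds could not make. The step is tied to the double bond because nothing else separates the pair: the fact that compounds 3 and 4 differ only in the configuration as drawn. With the double bond drawn E, 2-oxoimidazolidin-1-yl in place of (ethylcarbamoyl)amino reads a 1.3-fold lower number from compound 2 to compound 4 (0.10 log units; within the scatter), so this swap alone does not set compound 4 apart from compound 2.

Open, as far as these compounds go, is whether a Z double bond gives a similarly low number with (ethylcarbamoyl)amino. Also open, from the compounds shown here alone, is whether an amine or a methoxy group in place of the methyl groups would keep it.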